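The source may report more compounds than this note shows. Statements on the series, on what has been measured and on what is new or still open speak of the compounds shown alone.

Measured in a functional assay on A549 cells (Homo sapiens) for inhibition, read by MTT assay, with a stated time of 72 h; a higher number here means a weaker inhibitor, a lower number a stronger inhibitor:
Compound 1 `CNC(=O)CCCCCCCn1nc(-c2cnc3[nH]ccc3c2)c2c(N)ncnc21`: 51000 nM
Compound 2 `Nc1nc2cc(-c3nn(CCCC(=O)NO)c4ncnc(N)c34)ccc2o1`: > 100000 nM, a limit of the assay
Compound 3 `Nc1ncnc2c1c(-c1cnc3[nH]ccc3c1)nn2CCCCCC(=O)NO`: > 150000 nM, a limit of the assay

Compound 2 has no actual number, only the limit > 100000 nM. Compound 4 `Nc1nc2cc(-c3nn(CCCCC(=O)NO)c4ncnc(N)c34)ccc2o1` differs from it in one place: (hydroxycarbamoyl)methyl in place of hydroxycarbamoyl on a saturated chain carbon, three bonds along the chain from an aromatic nitrogen. This puts (hydroxycarbamoyl)methyl in place of hydroxycarbamoyl on a saturated chain carbon, three bonds along the chain from an aromatic nitrogen, so 3-(hydroxycarbamoyl)propyl becomes 4-(hydroxycarbamoyl)butyl. Among the compounds with values here, no measured step makes this same change. The nearest is an at least 2.9-fold higher number from compound 1 to compound 3 (0.46 log units; beyond the scatter), a different change on the core of compound 1, and it points to weak inhibition. In this assay the expected result is a step that the limit leaves unreadable from compound 2 to compound 4, with no change expected beyond the scatter. For compound 4 the estimate is 110000 nM, with an expected range from 45000 nM to 220000 nM.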

Compound 4, half-maximal inhibitory concentration: > 100000 nM
Compound 4: a limit, no number; the forecaster's own chance of this, stated with the estimate: 60%; the middle value does not contradict the limit.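

Compound 2 gives > 100000 nM, a limit of the assay. Compound 4 gives > 100000 nM, also a limit. Within the data shown here, no step from compound 2 to compound 4 can be read. The compounds shown leave open whether 4-(hydroxycarbamoyl)butyl and 3-(hydroxycarbamoyl)propyl differ at all in this assay.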